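Aryl swap at a limit of the read-out

This account rests on a few compounds, and the source may have more. Where it says the series, first, only, none or still open, it means among the compounds named here.

Values in a physicochemical assay for solubility, in phosphate buffer, at pH 7.4; on this read-out higher numbers stand for higher solubility and lower numbers for lower solubility:
- Compound 1 `OC1CN(c2nccnc2OC2CN(c3ccc4ccccc4n3)C2)C1`: 41000 nM
- Compound 2 `c1ccc(-c2nccnc2OC2CN(c3ccc4ccccc4n3)C2)cc1`: < 1000 nM, a limit

Compound 2 stands only at the limit of < 1000 nM in this assay, at which 1 of the 2 values shown sits. Compound 3 `Cc1ncccc1-c1nccnc1OC1CN(c2ccc3ccccc3n2)C1` differs from it in one place: 2-methylpyridin-3-yl in place of phenyl on an aromatic carbon. Among the measured compounds shown here, one measured step bears on this place: an at least 41-fold lower number from compound 1 to compound 2 (1.61 log units; beyond the scatter), large and beyond the scatter. That step shows how far this assay can move here, but a different group enters now, so only a modest move to a higher number is expected. The expected step is an at least 2.0-fold higher number from compound 2 to compound 3 (0.30 log units; that floor lies within the scatter). Compound 3 is estimated at 2000 nM, with an expected range of 500 nM to 10000 nM.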

Compound 3, solubility: 253000 nM
Compound 3: the middle estimate sits 130-fold (2.10 log units) below what was measured, and the stated range ends below it.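

At this place on the shared core, an aryl group does not by itself fix the read-out in this assay: 2-methylpyridin-3-yl in place of phenyl gives an at least 250-fold higher number from compound 2 to compound 3 (2.40 log units; beyond the scatter). Compound 2 is a limit, so that step gives only a floor: the limit of < 1000 nM in this assay, at which 1 of the 3 values shown sits. An aryl group can also exceed the 3-hydroxyazetidin-1-yl group here, with a 6.2-fold higher number from compound 1 to compound 3 (0.79 log units; beyond the scatter).

From the compounds shown here alone, whether the ring nitrogen or the methyl carries the step stays open. A 2-methylphenyl or a pyridin-3-yl group at this place would separate the two.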